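The source may hold more compounds than are shown below. What is called first, only, known or untested is meant among the compounds shown, and "the series" means these compounds.

Measured in a physicochemical assay for lipophilicity, at pH 7.4; on this read-out higher numbers stand for higher lipophilicity and lower numbers for lower lipophilicity:
- compound 1 `Cc1cc(Nc2ccc(S(F)(F)(F)(F)F)cc2)n2nc(C3CC3)nc2n1`: 3.5
- compound 2 `CCOc1nc2nc(C)cc(Nc3ccc(C(F)(F)F)cc3)n2n1`: 3.1
- compound 3 `COCc1nc2nc(C)cc(Nc3ccc(S(F)(F)(F)(F)F)cc3)n2n1`: 2.8

Compound 3 stands within the scatter of compound 2, while compound 1 lies clearly higher, beyond the scatter. The next compound to read is compound 4 `CCOc1nc2nc(C)cc(Nc3ccc(S(F)(F)(F)(F)F)cc3)n2n1`, which has the same atoms as compound 3, joined differently: ethoxy in place of methoxymethyl on an aromatic carbon.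

For the measured compounds named here, one measured step touches this carbon: a number 0.70 log units lower from compound 1 to compound 3 (beyond the scatter), with methoxymethyl in place of cyclopropyl. It shows that a change here can move this assay beyond the scatter, but it does not involve ethoxy, and the swap itself has not been measured. Compound 2 carries ethoxy with a different group elsewhere on the shared core. Compound 4 joins that ethoxy to the group shared by compound 1 and compound 3, so a value within their span is expected, which points to a modest rise. The expected step is a number 0.40 log units higher from compound 3 to compound 4 (beyond the scatter), an estimate only. For compound 4 the estimated value is 3.2, with an expected range from 2.8 to 3.6.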

Compound 4, distribution coefficient: 3.4
For compound 4 the middle estimate is 0.20 log units below the measured one, and the stated range covers the measured number.
By their numbers in this assay, from the lowest: compounds 3, 2, 4 and 1 (each within the scatter of the next, the first and the last beyond it).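

In this assay, ethoxy in place of methoxymethyl gives a number 0.60 log units higher from compound 3 to compound 4 (beyond the scatter), so on this aromatic carbon between two ring nitrogen atoms, joining the same atoms differently is enough to shift the read-out beyond the scatter. Ethoxy in place of cyclopropyl on the same carbon gives a number 0.10 log units lower from compound 1 to compound 4 (within the scatter), which leaves methoxymethyl as the one group of the three set apart from the others in this assay. With ethoxy held constant, the group of 6 heavy atoms in place of the group of 4 heavy atoms gives a number 0.30 log units higher from compound 2 to compound 4 (within the scatter), so that change on the other aromatic carbon is not resolved here.

Nothing at hand explains the gap between ethoxy and methoxymethyl. Going by these compounds, whether an amine or a longer ether chain on this carbon would fall in the ethoxy range or the methoxymethyl range remains open.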